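Replacing the chlorophenyl of compound 2 with a pyrrole ring

The source may hold more compounds than are shown below. What is called first, only, known or untested is meant among the compounds shown, and "the series" means these compounds.

Measured so far:
- compound 1 `CC1=CC[C@H](C(C)(C)NC(=S)N/N=C/c2ccccc2O)CC1` gives 10600 nM in a functional assay on U-251 cells (Homo sapiens) for inhibition, read by sulforhodamine B assay, with a stated time of 48 h; a lower number here means a stronger inhibitor of growth, a higher number a weaker inhibitor of growth
- compound 2 `CC1=CC[C@H](C(C)(C)NC(=S)N/N=C/c2ccc(Cl)cc2)CC1` is reported in this assay only as the limit > 100000 nM

Compound 2 therefore stands at the edge of what this assay can report: for it there is no number, only a limit (the limit of > 100000 nM in this assay, at which 1 of the 2 values shown sits). Within the data shown here, the one measured step, an at least 9.4-fold higher number from compound 1 to compound 2 (0.97 log units; beyond the scatter), concerns the same position and shows that exchanging the group on the carbon with a double bond to nitrogen can move the read-out a long way.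

Compound 3 `CC1=CC[C@H](C(C)(C)NC(=S)N/N=C/c2ccc[nH]2)CC1` differs from compound 2 by 1H-pyrrol-2-yl in place of 4-chlorophenyl on a carbon with a double bond to nitrogen. Compound 1 and compound 3 both carry one hydrogen-bond donor on that ring, compound 2 none, but nothing measured here ties the donor count to growth inhibition. Because compound 2 sits at the limit, the step to compound 3 can only be a lower number or no change beyond the scatter. A modest move toward compound 1 is expected, an at least 2.5-fold lower number from compound 2 to compound 3 (0.39 log units; beyond the scatter), with a real chance that compound 3 again only reaches the limit. The estimate for compound 3 is 40000 nM, between 10000 nM and 100000 nM.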

Compound 3, concentration for total growth inhibition: 3900 nM
Compound 3: middle estimate off by 10-fold (1.01 log units), on the high side, and the stated range ends above it.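

In this assay, the 1H-pyrrol-2-yl group gives the first comparison at this position in which both compounds have a real number, and it shows that the 2-hydroxyphenyl group of compound 1 is not the best group shown here: a 2.7-fold lower number from compound 1 to compound 3 (0.43 log units; beyond the scatter). The change from the 4-chlorophenyl group is much larger, an at least 25-fold lower number from compound 2 to compound 3 (1.40 log units; beyond the scatter), so a five-membered aromatic ring with a nitrogen atom can bring back growth inhibition that is lost with the chlorinated ring. That step gives only a minimum size, because compound 2 is reported only as a limit and not as a number: the limit of > 100000 nM in this assay, at which 1 of the 3 values shown sits.

The three compounds leave open what drives the gain, since the 1H-pyrrol-2-yl group differs from the 4-chlorophenyl group at once in ring size, in its ring atoms and in its hydrogen-bond donor. A furan-2-yl ring, with oxygen in the ring instead of nitrogen, or a 1-methylpyrrol-2-yl group, with a methyl on the ring nitrogen, would be the kind of comparison that could begin to separate these differences.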